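From isopropyl to diethylamino on a sulfonyl sulfur

A few compounds are considered here, and "the series" means these few. Any claim that something is new, unique, unknown or untested is made for them only; others in the source may bear on it.

Among the measured compounds shown here, in a functional assay on MIA PaCa-2 cells (Homo sapiens) for inhibition, read by MTT assay, with a stated time of 7 days (a higher number here means a weaker inhibitor, a lower number a stronger inhibitor), compound 3 `CC(C)c1noc(N2CCN(C(=O)[C@@H]3CCCN(S(=O)(=O)c4ccc(S(=O)(=O)C(C)C)cc4)C3)CC2)n1` gives 70 nM, the lowest of the three numbers measured so far. Compound 1 `CCN(CC)S(=O)(=O)c1ccc(S(=O)(=O)N2CCC[C@@H](C(=O)N3CCN(c4nc(C(F)(F)F)no4)CC3)C2)cc1` gives 600 nM and compound 2 `CC(C)c1noc(N2CCN(C(=O)[C@@H]3CCCN(S(=O)(=O)c4ccc(S(=O)(=O)NC5CC5)cc4)C3)CC2)n1` gives 1000 nM, both clearly higher. Compound 4 `CCN(CC)S(=O)(=O)c1ccc(S(=O)(=O)N2CCC[C@@H](C(=O)N3CCN(c4nc(C(C)C)no4)CC3)C2)cc1` has not yet been measured. It differs from compound 3 in having diethylamino in place of isopropyl on a sulfonyl sulfur.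

For the measured compounds named here, one measured step bears directly on this change. It is a 14-fold lower number from compound 2 to compound 3 (1.15 log units; beyond the scatter), a large step with isopropyl in place of cyclopropylamino on a sulfonyl sulfur. The change now in question runs the opposite way, from isopropyl to an amino group, though not the same amino group. The other guide is compound 1, which gives 600 nM and carries the diethylamino group of compound 4, but it also differs from compound 4 elsewhere. Going by the values given here, no measured pair isolates diethylamino, so the size of the change remains uncertain.

A rise beyond the scatter is expected in this assay, probably smaller than the measured step, and it is estimated as a 5.0-fold higher number from compound 3 to compound 4 (0.70 log units; beyond the scatter). Compound 4 is expected at 350 nM, with an estimated range of 120 nM to 1000 nM.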

Compound 4, half-maximal inhibitory concentration: 50 nM
For compound 4 the middle estimate is 7.0-fold (0.85 log units) above the measured one, outside the stated range (below it).
By their numbers in this assay, from the lowest: compounds 4 and 3 (each within the scatter of the next); then compounds 1 and 2 (each within the scatter of the next).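

Read through this assay, the exchange of isopropyl for diethylamino on this sulfonyl sulfur gives a 1.4-fold lower number from compound 3 to compound 4 (0.15 log units; within the scatter) and so shows that an amino group here need not cost anything, since the two groups cannot be told apart in this assay. The contrast with cyclopropylamino is large, with a 20-fold lower number from compound 2 to compound 4 (1.30 log units; beyond the scatter) at the same place, so the earlier rise tied to cyclopropylamino, seen as a 14-fold lower number from compound 2 to compound 3 (1.15 log units; beyond the scatter) in the reverse sense, belongs to that particular group and not to amino groups on this sulfur in general. With diethylamino held constant, the other end of the molecule also matters, as a 12-fold lower number from compound 1 to compound 4 (1.08 log units; beyond the scatter) shows for isopropyl in place of trifluoromethyl on an aromatic carbon, and so the higher value of compound 1 goes with the trifluoromethyl group and not with diethylamino.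

Nothing shown gives a reason for any of these steps. From the compounds shown here alone, it stays open whether dimethylamino, a longer chain such as dipropylamino, or an unsubstituted amine on this sulfur would match diethylamino, and whether trifluoromethyl would carry the same penalty alongside isopropyl on the sulfonyl sulfur.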